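Furan in place of methoxyphenyl on the hydrazone carbon

This account rests on a few compounds, and the source may have more. Where it says the series, first, only, none or still open, it means among the compounds named here.

Of the compounds shown here, three sharing one core have been measured in a functional assay on A549 cells (Homo sapiens) for cytotoxicity, read by MTT assay, with a stated time of 48 h; a higher number here means a more soluble compound, a lower number a less soluble compound. Compound 1 `O=C(N/N=C/c1ccco1)c1cc(-c2ccccc2)nn1Cc1ccc(Cl)nc1` gives 50000 nM, compound 2 `O=C(N/N=C/c1ccccc1O)c1cc(-c2ccc(Cl)cc2)nn1Cc1ccc(Cl)nc1` gives 22500 nM, and compound 3 `COc1ccc(/C=N/NC(=O)c2cc(-c3ccc(Cl)cc3)nn2Cc2ccc(Cl)nc2)cc1` gives 3300 nM in this assay. Compound 3 stands lowest of the three: compound 2 is its nearest neighbour and compound 1 is furthest away, both steps lying beyond the scatter. Among the compounds with values here, the one step that joins two measured compounds differing in a single place, a 6.8-fold lower number from compound 2 to compound 3 (0.83 log units; beyond the scatter), concerns the group on the carbon with a double bond to nitrogen.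

Compound 4 `O=C(N/N=C/c1ccco1)c1cc(-c2ccc(Cl)cc2)nn1Cc1ccc(Cl)nc1` differs from compound 3 at that same place: furan-2-yl in place of 4-methoxyphenyl on a carbon with a double bond to nitrogen. Within the data shown here, no measured step covers this exchange directly, so the expectation rests on what the values show. Compound 1 also carries a furan-2-yl there and gives a high number, and compound 3 carries the 4-methoxyphenyl and gives the lowest. Compound 4 is therefore expected to move back toward higher numbers, a step of a 6.1-fold higher number from compound 3 to compound 4 (0.78 log units; beyond the scatter) in this assay. Compound 4 is estimated at 20000 nM, within a range from 5000 nM to 60000 nM.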

Compound 4, solubility: 70000 nM
Compound 4: the middle estimate sits 3.5-fold (0.54 log units) below what was measured; measured number outside the range, above it.
By their numbers in this assay, from the lowest: compound 3; then compound 2; then compounds 1 and 4 (each within the scatter of the next).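

On the shared core, the group on the carbon with a double bond to nitrogen now spans a wide range in this assay: there is a 21-fold higher number from compound 3 to compound 4 (1.33 log units; beyond the scatter) and a 3.1-fold higher number from compound 2 to compound 4 (0.49 log units; beyond the scatter), which places furan-2-yl above both 2-hydroxyphenyl and 4-methoxyphenyl. Within the data shown here, the chloro group, read here for the first time, makes no difference beyond the usual scatter while furan-2-yl is in place, with a 1.4-fold higher number from compound 1 to compound 4 (0.15 log units; within the scatter). Nothing available explains why these exchanges at the carbon have the effects seen.

As far as these compounds go, whether the chloro group would remain as silent with 4-methoxyphenyl or 2-hydroxyphenyl on that carbon stays open. So does whether the high number belongs to furan-2-yl in particular, or would also appear with thiophen-2-yl or an unsubstituted phenyl there.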